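Trading formylamino for trifluoromethyl on the shared core

A few compounds are considered here, and "the series" means these few. Any claim that something is new, unique, unknown or untested is made for them only; others in the source may bear on it.

In a functional assay on HCT-116 cells (Homo sapiens) for inhibition, read by sulforhodamine B assay (a lower number here means a stronger inhibitor, a higher number a weaker inhibitor), compound 1 `CC(C)(C)Nc1nc(C(F)(F)F)nc2ccccc12` gives 20600 nM. Adding a hydroxy group to an aromatic carbon of this core gives compound 2 `CC(C)(C)Nc1nc(C(F)(F)F)nc2ccc(O)cc12`, which reads 7300 nM. Adding a formylamino group instead gives compound 3 `CC(C)(C)Nc1nc(C(F)(F)F)nc2ccc(NC=O)cc12`, which reads 5720 nM. Compound 3 therefore stands well clear of the first compound, with a 3.6-fold lower number from compound 1 to compound 3 (0.56 log units; beyond the scatter), but it cannot be separated from its hydroxy relative, since a 1.3-fold lower number from compound 2 to compound 3 (0.11 log units; within the scatter) stays within the scatter.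

The next compound is compound 4 `CC(C)(C)Nc1nc(C(F)(F)F)nc2ccc(C(F)(F)F)cc12`, with trifluoromethyl in place of formylamino on an aromatic carbon. Two measured steps suggest what to expect. Adding a group gave modest gains, a 2.8-fold lower number from compound 1 to compound 2 (0.45 log units; beyond the scatter) and a 3.6-fold lower number from compound 1 to compound 3 (0.56 log units; beyond the scatter), and exchanging one added group for the other, a 1.3-fold lower number from compound 2 to compound 3 (0.11 log units; within the scatter), made no clear difference. Trifluoromethyl itself has not been tested on this core, so the expectation is uncertain and leans slightly back toward compound 1. In this assay, the expected change is small and within the scatter, a 1.6-fold higher number from compound 3 to compound 4 (0.20 log units; within the scatter). Compound 4 is estimated to read 9000 nM, with an expected range from 3500 nM to 23000 nM.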

Compound 4, half-maximal inhibitory concentration: 18600 nM
Compound 4: middle estimate off by 2.1-fold (0.32 log units), on the low side; the range from low to high includes it.
By their numbers in this assay, from the lowest: compounds 3 and 2 (each within the scatter of the next); then compounds 4 and 1 (each within the scatter of the next).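

At this position on the shared core, adding a group does not by itself lower the number: in this assay, trifluoromethyl in place of hydrogen brings no clear change (a 1.1-fold lower number from compound 1 to compound 4 (0.04 log units; within the scatter)), unlike the hydroxy and formylamino groups. Set against those two groups, trifluoromethyl gives back the earlier gain, with modest rises beyond the scatter (a 3.3-fold higher number from compound 3 to compound 4 (0.51 log units; beyond the scatter); a 2.5-fold higher number from compound 2 to compound 4 (0.41 log units; beyond the scatter)), so the identity of the added group matters here, and the gain does not extend to every group placed at this carbon. Formylamino carries a hydrogen-bond donor and a hydrogen-bond acceptor and trifluoromethyl carries neither, but no measurement available here links that difference to the change in the number.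

Still open, from the compounds shown here alone, is how an amine, a methoxy group or a carboxylic acid at this position would read, and whether a longer acyl chain in place of the formyl part of formylamino would hold the lower number. Also open is whether trifluoromethyl would leave the number unchanged on other carbons of the shared core, since only this one position is shown.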